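The compounds below may be only part of what the source reports. "The series", "measured", "known", "first", "only" and "open" are said of these compounds alone.

Measured in a functional assay on HeLa cells (Homo sapiens) for inhibition, read by MTT assay, with a stated time of 72 h; a higher number here means a weaker inhibitor, a lower number a stronger inhibitor:
Compound 1 `COc1cc(NC(C)CCCNC(=O)Nc2cccc(Cl)c2)c2ncccc2c1`: 17000 nM
Compound 2 `COc1cc(NC(C)CCCNC(=O)NNC(=O)Nc2ccc(F)cc2)c2ncccc2c1`: >= 250000 nM, a limit of the assay and not a number
Compound 3 `COc1cc(NC(C)CCCNC(=O)NNC(=O)Nc2cccc(C(F)(F)F)c2)c2ncccc2c1`: 4900 nM

Within the data shown here, only two of these values are true numbers. Compound 3, at 4900 nM, has the lower of them, and compound 1 stands higher at 17000 nM.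

Compound 4 `COc1cc(NC(C)CCCNC(=O)NNC(=O)Nc2cccc(Cl)c2)c2ncccc2c1` keeps everything in compound 3 except one group, with chloro in place of trifluoromethyl on an aromatic carbon.

Among the measured compounds shown here, two measured steps bear on this change. The closer one is an at least 51-fold lower number from compound 2 to compound 3 (1.70 log units; beyond the scatter), large and made on the same chain by exchanging 4-fluorophenyl for 3-(trifluoromethyl)phenyl. The other is an at least 14-fold higher number from compound 1 to compound 2 (1.16 log units; beyond the scatter), also large, but it changes more than the ring substituent. Both run through compound 2, so they rest on (the limit of >= 250000 nM in this assay, at which 1 of the 3 values shown sits). Neither shows what an exchange of chloro for trifluoromethyl does.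

Compound 1 already carries the 3-chlorophenyl group and gives 17000 nM, so this group is compatible with a measurable number. The substituent in compound 4 also stays in the same place as in compound 3. In this assay, a large loss is therefore not expected, only a slight drift towards a higher number. The expected change is a 1.4-fold higher number from compound 3 to compound 4 (0.15 log units; within the scatter), which would not clearly exceed the scatter.

For compound 4 the estimate is 7000 nM, with an expected range from 2000 nM to 25000 nM.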

Compound 4, half-maximal inhibitory concentration: 44000 nM
The estimate for compound 4 lay 6.3-fold (0.80 log units) below the measured number; the whole stated range lies below it.
By their numbers in this assay, from the lowest: compound 3; then compound 1; then compound 4. At a limit, above all of these: compound 2.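

In this assay, chloro and trifluoromethyl can now be compared directly on the same chain, and the exchange is not neutral: a 9.0-fold higher number from compound 3 to compound 4 (0.95 log units; beyond the scatter), so at this place on the ring trifluoromethyl gives the stronger inhibitor of the two. With 3-chlorophenyl held fixed, the chain itself can also be judged, and ((3-chlorophenyl)carbamoyl)amino in place of 3-chlorophenyl gives a 2.6-fold higher number from compound 1 to compound 4 (0.41 log units; beyond the scatter), a modest loss that shows the change of chain alone does not abolish inhibition. The value at the start of an at least 5.6-fold lower number from compound 2 to compound 4 (0.75 log units; beyond the scatter) is a limit and not a number, so that step gives only a minimum size, and it changes both the substituent and its place on the ring: the limit of >= 250000 nM in this assay, at which 1 of the 4 values shown sits.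

The compounds shown leave open whether trifluoromethyl would also give a lower number than chloro on the chain of compound 1, since the comparison rests on a single pair. They also leave open how other groups at this place, such as a nitrile, an amine or a carboxylic acid, would compare with chloro and trifluoromethyl.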